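The source may report more compounds than this note shows. Statements on the series, on what has been measured and on what is new or still open speak of the compounds shown alone.

Three measured compounds share one core and differ only in the ester attached to it. Compound 3 `C=C1C(=O)[C@@]23C(=O)OC[C@]4([C@@H](OC(C)=O)CCC(C)(C)[C@H]4C=O)[C@@H]2CC[C@H]1[C@H]3OC(=O)c1ccccc1` carries a plain benzoate, and in a functional assay on K562 cells (Homo sapiens) for inhibition, read by MTT assay (a higher number here means a weaker inhibitor, a lower number a stronger inhibitor), compound 3 gives 1400 nM, the lowest of the three numbers. Compound 1 `C=C1C(=O)[C@@]23C(=O)OC[C@]4([C@@H](OC(C)=O)CCC(C)(C)[C@H]4C=O)[C@@H]2CC[C@H]1[C@H]3OC(=O)c1ccc(OC)cc1` adds a methoxy to the ring, and in this assay compound 1 gives 1920 nM. Compound 2 `C=C1C(=O)[C@@]23C(=O)OC[C@]4([C@@H](OC(C)=O)CCC(C)(C)[C@H]4C=O)[C@@H]2CC[C@H]1[C@H]3OC(=O)c1ccc(C(F)(F)F)cc1` adds a trifluoromethyl instead, and in this assay compound 2 gives 3150 nM. The step of a 1.4-fold lower number from compound 1 to compound 3 (0.14 log units; within the scatter) lies within the scatter, while a 2.3-fold lower number from compound 2 to compound 3 (0.35 log units; beyond the scatter) is a modest step beyond it, so compound 3 and compound 1 cannot be ordered, and compound 3 stands apart only from compound 2.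

Compound 4 `C=C1C(=O)[C@@]23C(=O)OC[C@]4([C@@H](OC(C)=O)CCC(C)(C)[C@H]4C=O)[C@@H]2CC[C@H]1[C@H]3OC(=O)CC` takes a different kind of step: ethyl in place of phenyl on a carbonyl carbon. The change from compound 3 to compound 4 removes the ring altogether rather than decorating it, so the measured steps, all swaps of a single ring substituent, bear on it only loosely. They show that changes at this ester have so far moved this assay by small amounts in either direction, so a step of similar modest size is expected, with no firm direction. Compound 4 is therefore estimated at 2000 nM, in a range from 700 nM to 6000 nM, which is expected to mean a step of a 1.4-fold higher number from compound 3 to compound 4 (0.15 log units; within the scatter).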

Compound 4, half-maximal inhibitory concentration: 1500 nM
Compound 4: the middle estimate sits 1.3-fold (0.12 log units) above what was measured; the range from low to high includes it.
By their numbers in this assay, from the lowest: compounds 3, 4, 1 and 2 (each within the scatter of the next, the first and the last beyond it).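

Replacing the aromatic ring of the ester with ethyl on the carbonyl carbon gives in this assay a 1.1-fold higher number from compound 3 to compound 4 (0.03 log units; within the scatter), so among these compounds, an aromatic ring at this position is not required for a number of this size. The other two comparisons, a 1.3-fold lower number from compound 1 to compound 4 (0.11 log units; within the scatter) and a 2.1-fold lower number from compound 2 to compound 4 (0.32 log units; beyond the scatter), show that compound 2 alone stands apart from compound 4, and only by a modest step, while compound 1, compound 3 and compound 4 cannot be ordered among themselves. Nothing further is available here to explain how this ester position accepts so large a change in the group it carries.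

On these data alone, what remains open is how far this tolerance extends, for example to a longer chain such as butanoyl, to a chain ending in an amine or a carboxylic acid, or to a free hydroxyl group in place of the whole ester. As far as these compounds go, it is also open whether the same indifference to the ester would hold if another part of the shared core were changed.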